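Removing the ortho hydroxy from a dihydroxy thiosemicarbazone

A few compounds are considered here, and "the series" means these few. Any claim that something is new, unique, unknown or untested is made for them only; others in the source may bear on it.

Three thiosemicarbazones have been measured in a functional assay on MDA-MB-231 cells (Homo sapiens) for inhibition, read by WST assay, with a stated time of 48 h; on this read-out higher numbers stand for weaker inhibition and lower numbers for stronger inhibition. Compound 1 `Oc1ccc(/C=N\NC(=S)NC2CCCCC2)c(O)c1` gives 56600 nM, the second highest of the three numbers. Compound 2 `O=[N+]([O-])c1ccccc1/C=N\NC(=S)NC1CCCCC1` gives 118000 nM, a higher number than compound 1, while compound 3 `Oc1cccc(/C=N\NC(=S)NC2CCCCC2)c1` gives 24500 nM, a lower one. Compound 4 `Oc1ccc(/C=N\NC(=S)NC2CCCCC2)cc1` is not yet measured. It differs from compound 1 by hydrogen in place of hydroxy on an aromatic carbon. Among the compounds with values here, no step between measured compounds isolates this change. Compound 3, which carries a single hydroxy, gives a lower number than compound 1, so a modest decrease is expected, a 1.4-fold lower number from compound 1 to compound 4 (0.15 log units; within the scatter), though it may well fall within the scatter. Compound 4 is estimated at 40000 nM, with a range from 15000 nM to 110000 nM.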

Compound 4, half-maximal inhibitory concentration: 115000 nM
Beside the measured number, compound 4's estimate is 2.9-fold (0.46 log units) below it; measured number above the stated range.
By their numbers in this assay, from the lowest: compound 3; then compound 1; then compounds 4 and 2 (each within the scatter of the next).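

In this assay, within the data shown here, placing hydrogen instead of hydroxy on the aromatic carbon ortho to a large group gives a 2.0-fold higher number from compound 1 to compound 4 (0.31 log units; beyond the scatter), the first step that isolates this position. Here the hydroxy goes with stronger inhibition, and losing it moves the number beyond the scatter. Nothing available accounts for this difference.

The compounds shown leave open whether a methoxy group or an amine on this carbon would keep the lower number. They also leave open whether the hydroxy counts equally once the other hydroxy is replaced by hydrogen.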